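From 4-chlorophenyl to 3-hydroxyphenyl on an aromatic nitrogen

This account rests on a few compounds, and the source may have more. Where it says the series, first, only, none or still open, it means among the compounds named here.

Compound 1 `C/C(=C\CC/C(C)=C/CC[C@@H]1[C@@]2(C)CCC(=O)C(C)(C)[C@H]2CC[C@@]1(C)O)CC/C=C(\C)C(=O)OCc1cn(-c2ccc(F)c(Cl)c2)nn1` and compound 2 `C/C(=C\CC/C(C)=C/CC[C@@H]1[C@@]2(C)CCC(=O)C(C)(C)[C@H]2CC[C@@]1(C)O)CC/C=C(\C)C(=O)OCc1cn(-c2ccc(Cl)cc2)nn1` share one core and differ only in the aryl group on an aromatic nitrogen. In an ADME assay on L132 cells (Homo sapiens) for cytotoxicity, read by MTT assay, with a stated time of 48 h (on this read-out higher numbers stand for weaker inhibition and lower numbers for stronger inhibition), compound 1 gives > 150000 nM, which is a limit and not a number. Compound 2 gives > 150000 nM, which is also a limit. Compound 2 therefore stands at the limit of > 150000 nM in this assay, at which 2 of the 2 values shown sit, with no exact reading to rank it by. Going by the values given here, the only measured step is a step that the two limits leave unreadable from compound 1 to compound 2, so 4-chlorophenyl in place of 3-chloro-4-fluorophenyl offers no size to carry forward.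

Compound 3 `C/C(=C\CC/C(C)=C/CC[C@@H]1[C@@]2(C)CCC(=O)C(C)(C)[C@H]2CC[C@@]1(C)O)CC/C=C(\C)C(=O)OCc1cn(-c2cccc(O)c2)nn1` carries 3-hydroxyphenyl in place of 4-chlorophenyl on an aromatic nitrogen, and the difference reads (3-hydroxyphenyl in place of 4-chlorophenyl on an aromatic nitrogen). The core stays the same. The expectation rests on compound 2, whose limit is > 150000 nM, and no step beyond the scatter is expected in this assay, though a reading at the limit would again hide any true size. The expected outcome is a number no higher from compound 2 to compound 3 (the limit leaves the size open). Compound 3 is estimated at 150000 nM, with an expected range from 60000 nM to 300000 nM.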

Compound 3, half-maximal inhibitory concentration: 146000 nM
Beside the measured number, compound 3's estimate is 1.0-fold (0.01 log units) above it; the range from low to high includes it.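

Going by these compounds alone, compound 3 is the first compound here to give an exact reading in this assay, so an aryl group on this aromatic nitrogen can now be tied to a number rather than a limit. The change to 3-hydroxyphenyl gives an at least 1.0-fold lower number from compound 2 to compound 3 (0.01 log units; that floor lies within the scatter), and the change from the chloro-fluoro aryl group gives an at least 1.0-fold lower number from compound 1 to compound 3 (0.01 log units; that floor lies within the scatter); both are floors only, so bringing in the hydroxyl group, with the hydrogen-bond donor and acceptor counted for 3-hydroxyphenyl, shows no step beyond the scatter. The 4-chlorophenyl of compound 2 and the 3-chloro-4-fluorophenyl of compound 1 still give limits and not numbers: the limit of > 150000 nM in this assay, at which 2 of the 3 values shown sit.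

From the compounds shown here alone, how far compound 1 and compound 2 truly lie from compound 3 stays open, and the step between compound 1 and compound 2 cannot be read at all, so the real size of each change remains unknown. Also open, going by these compounds, is how an amine, a carboxylic acid or a methoxy group on the same aryl ring would read, and whether any group at this position can give a step beyond the scatter.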